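Halogen exchange on the five-membered ring of compound 2

This account rests on a few compounds, and the source may have more. Where it says the series, first, only, none or still open, it means among the compounds named here.

Measured so far in a functional assay on the whole organism with Rattus norvegicus as the target; on this read-out lower numbers stand for an effect already at smaller amounts and higher numbers for an effect only at larger amounts of compound:
compound 1, `Cc1cc(C)n2nccc2n1`: 60.3 mg/kg
compound 2, `Cc1cc(C)n2ncc(Cl)c2n1`: 31.8 mg/kg

Within the data shown here, compound 2 has only one measured neighbour, compound 1, and the step of a 1.9-fold lower number from compound 1 to compound 2 (0.28 log units; within the scatter) lies within the scatter, so the two values cannot be set apart on this read-out. Among the measured compounds shown here, no measured compound carries a halogen other than chloro at this position.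

Compound 3, `Cc1cc(C)n2ncc(Br)c2n1`, differs from compound 2 in one place: bromo in place of chloro on an aromatic carbon. For the measured compounds named here, no measured step bears directly on this exchange; the only step available, a 1.9-fold lower number from compound 1 to compound 2 (0.28 log units; within the scatter), concerns hydrogen to chloro and stayed within the scatter. With a change of this size at a position where the shown step was small, the expected step of a 1.1-fold lower number from compound 2 to compound 3 (0.06 log units; within the scatter) is none beyond the scatter. For compound 3 the estimate in this assay is therefore 28 mg/kg, with a range from 14 mg/kg to 60 mg/kg.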

Compound 3, dose for half-maximal effect: 29.5 mg/kg
Compound 3: the middle estimate sits 1.1-fold (0.02 log units) below what was measured; measured number inside the range.
By their numbers in this assay, from the lowest: compounds 3, 2 and 1 (each within the scatter of the next, the first and the last beyond it).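

In (this assay) the exchange of chloro for bromo on this aromatic carbon gives (a 1.1-fold lower number from compound 2 to compound 3 (0.03 log units; within the scatter)), so the two halogens cannot be set apart on this read-out. Among these compounds, measured against the hydrogen of compound 1, however, bromo gives (a 2.0-fold lower number from compound 1 to compound 3 (0.31 log units; beyond the scatter)), the first step at this position printed as beyond the scatter, although a modest one, whereas the chloro step (a 1.9-fold lower number from compound 1 to compound 2 (0.28 log units; within the scatter)) stayed within it. The difference between these two halogens thus remains unresolved, and nothing available accounts for the outcome.

Open, from the compounds shown here alone, is whether fluoro or iodo on this carbon would fall with chloro and bromo on this read-out. Also open, going by these compounds, is whether a non-halogen group such as an amine, a nitrile or a longer chain would give a larger step from compound 1.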